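Lengthening the Chain from Compound 2 to Compound 3

This account rests on a few compounds, and the source may have more. Where it says the series, first, only, none or still open, it means among the compounds named here.

Compound 1 `COc1cc(C(c2ccc(O)c(OC)c2)[C@@H](CO)C(C)C)ccc1O` gives > 100000 nM as a limit of the assay
Compound 2 `CC[C@H](C(C)C)C(c1ccc(O)c(OC)c1)c1ccc(O)c(OC)c1` gives 9700 nM as a measured number

Going by the values given here, compound 2 holds the only actual number in a functional assay on HeLa cells (Homo sapiens) for cytotoxicity, read by WST assay, with a stated time of 48 h (on this read-out higher numbers stand for weaker inhibition and lower numbers for stronger inhibition), and compound 1 stands at a limit. Compound 3 `CCCCC[C@H](C(C)C)C(c1ccc(O)c(OC)c1)c1ccc(O)c(OC)c1` differs from compound 2 by propyl in place of hydrogen on a saturated chain carbon, four bonds along the chain from two aromatic carbons and so carries 1-isopropylhexyl in place of 1-isopropylpropyl. Among the compounds with values here, only one measured step bears on this chain, the large at least 10-fold lower number from compound 1 to compound 2 (1.01 log units; beyond the scatter) with 1-isopropylpropyl in place of 1-(hydroxymethyl)-2-methylpropyl. A smaller move in the same direction is expected in this assay as the estimated 2.4-fold lower number from compound 2 to compound 3 (0.38 log units; beyond the scatter) for the longer chain. Compound 3 is expected at 4000 nM (estimated range 1200 nM to 15000 nM).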

Compound 3, half-maximal inhibitory concentration: 9200 nM
Compound 3: middle estimate off by 2.3-fold (0.36 log units), on the low side, and the stated range covers the measured number.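

In this assay, propyl in place of hydrogen on this saturated chain carbon gives a 1.1-fold lower number from compound 2 to compound 3 (0.02 log units; within the scatter), so the longer chain of 1-isopropylhexyl reads the same as 1-isopropylpropyl. Going by these compounds alone, the replacement of 1-(hydroxymethyl)-2-methylpropyl by 1-isopropylhexyl still gives an at least 10-fold lower number from compound 1 to compound 3 (1.03 log units; beyond the scatter), a step of the same reach as the one to compound 2. That step starts from a limit, not a number: the limit of > 100000 nM in this assay, at which 1 of the 3 values shown sits.

As far as these compounds go, what remains open is whether a chain longer than 1-isopropylhexyl would move the number. From the compounds shown here alone, the effect of an amine or a carboxylic acid at the chain end also remains open.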